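The source may report more compounds than this note shows. Statements on the series, on what has been measured and on what is new or still open speak of the compounds shown alone.

Measured in a physicochemical assay for lipophilicity; on this read-out higher numbers stand for higher lipophilicity and lower numbers for lower lipophilicity:

- compound 1 `Cc1ccc(NC(=O)[C@H](COC(C)C)Oc2ncnc3c2cnn3-c2ccccc2Cl)nc1`: 3.9
- compound 2 `COC[C@H](Oc1ncnc2c1cnn2-c1ccccc1Cl)C(=O)Nc1ccc(C)cn1`: 3.4

Among the measured compounds shown here, of these two numbers, compound 2 holds the lower, and compound 1 is the only neighbour it can be read against. The next structure is compound 3 `COCC[C@H](Oc1ncnc2c1cnn2-c1ccccc1Cl)C(=O)Nc1ccc(C)cn1`, which departs from compound 2 as follows: methoxymethyl in place of methoxy on a saturated chain carbon, two bonds along the chain from a carbonyl carbon and an oxygen on an aromatic ring. In words, this is methoxymethyl in place of methoxy on a saturated chain carbon, two bonds along the chain from a carbonyl carbon and an oxygen on an aromatic ring. Cut one bond further out, it reads methoxymethyl to 2-methoxyethyl.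

For the measured compounds named here, only one measured step bears on this change: a number 0.50 log units lower from compound 1 to compound 2 (beyond the scatter), a modest drop with methyl in place of isopropyl on an oxygen on a saturated carbon. That step went to a smaller group, whereas compound 3 carries the larger one, so a rise in this assay is expected, though a smaller one than that drop. The expected step is a number 0.20 log units higher from compound 2 to compound 3 (within the scatter). In this assay the estimate for compound 3 is 3.6, with an expected range from 3.3 to 4.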

Compound 3, distribution coefficient: 3.6
Compound 3: middle estimate and measured number agree at the digits printed, within the range that was stated.
By their numbers in this assay, from the lowest: compounds 2, 3 and 1 (each within the scatter of the next, the first and the last beyond it).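

In this assay the move to the 2-methoxyethyl chain gives a number 0.20 log units higher from compound 2 to compound 3 (within the scatter), so at this position, on a saturated chain carbon, two bonds along the chain from a carbonyl carbon and an oxygen on an aromatic ring, the extra carbon in methoxymethyl does not separate the pair on this read-out. The comparison with the isopropoxy compound gives a number 0.30 log units lower from compound 1 to compound 3 (within the scatter), so this second change also stays inside the scatter, even though the earlier step between compound 1 and compound 2 lay beyond it; compound 3 therefore sits within the scatter of both, and only the two compounds at the ends of the series are resolved from each other. Nothing measured here offers a reason for the size of either step.

The compounds shown leave open whether a longer chain, such as a further methylene before the methoxy group, would produce a step beyond the scatter in this assay. They also leave open how an amine or a carboxylic acid at the end of this chain would read in the same assay, since every group shown so far ends in an ether oxygen with an alkyl group.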